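The source may hold more compounds than are shown below. What is called first, only, known or untested is meant among the compounds shown, and "the series" means these compounds.

Compound 1 `Clc1ccc2c(NCCCN3CCN(c4ccccc4)CC3)ccnc2c1`, compound 2 `FC(F)(F)c1ccc2c(NCCCN3CCN(c4ccccc4)CC3)ccnc2c1` and compound 3 `FC(F)(F)c1ccc2c(NCCCN3CCN(c4ccnc5cc(Cl)ccc45)CC3)ccnc2c1` share a quinoline-amine chain leading to a piperazine, and all three were tested in a functional assay on MCF7 cells (Homo sapiens) for antiproliferative activity, read by sulforhodamine B assay, with a stated time of 48 h; a higher number here means a weaker inhibitor of growth, a lower number a stronger inhibitor of growth. In this assay compound 1 gives 12800 nM, compound 2 gives 8750 nM and compound 3 gives 4600 nM. The change trifluoromethyl in place of chloro on an aromatic carbon gave a 1.5-fold lower number from compound 1 to compound 2 (0.17 log units; within the scatter); the change from compound 2 to compound 3 gave a 1.9-fold lower number from compound 2 to compound 3 (0.28 log units; within the scatter). The difference between the core of compound 1 and the core of compound 3 is not broken down here. Compound 4 `FC(F)(F)c1ccc2c(NCCCN3CCN(c4ccnc5cc(C(F)(F)F)ccc45)CC3)ccnc2c1` repeats the same change on compound 3: trifluoromethyl in place of chloro on an aromatic carbon. Since this change, made once already, gave a 1.5-fold lower number from compound 1 to compound 2 (0.17 log units; within the scatter), a step of similar size is expected here, namely a 1.3-fold higher number from compound 3 to compound 4 (0.12 log units; within the scatter). Compound 4 is therefore estimated at 6000 nM, likely between 2500 nM and 12000 nM.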

Compound 4, concentration for 50% growth inhibition: 17200 nM
Beside the measured number, compound 4's estimate is 2.9-fold (0.46 log units) below it; measured number outside the range, above it.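

In this assay, trifluoromethyl in place of chloro on an aromatic carbon did not behave the same way on both cores, giving a 3.7-fold higher number from compound 3 to compound 4 (0.57 log units; beyond the scatter). The two results for this one change differ by more than repeat measurements would normally account for: the same change on two cores in this assay, a 1.5-fold lower number (0.17 log units; within the scatter) from compound 1 to compound 2 and a 3.7-fold higher number (0.57 log units; beyond the scatter) from compound 3 to compound 4, 5.5-fold (0.74 log units) apart, beyond the scatter of two such steps. The size and direction of this step therefore did not carry over between these two cores, although two cases cannot show which structural difference between the cores matters, or how the change would behave on any further core.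

On these data alone, it remains open whether a smaller group such as fluoro or methyl, or a nitrile or an amine, at the same place would follow either step.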